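This account rests on a few compounds, and the source may have more. Where it says the series, first, only, none or still open, it means among the compounds named here.

Measured in an ADME assay on liver for metabolic stability, with Liver microsome (Homo sapiens) as the target, read by LC-MS, using microsomes; on this read-out lower numbers stand for slow clearance and higher numbers for fast clearance:
- compound 1 `CCCC[C@@H](O)C(=O)N1C[C@H]2C[C@H]2[C@H]1C(=O)NCc1cc(Cl)ccc1-n1cnnn1`: 32 mL.min-1.g-1
- compound 2 `O=C(NCc1cc(Cl)ccc1-n1cnnn1)[C@@H]1[C@H]2C[C@H]2CN1C(=O)[C@H](O)Cc1ccccc1`: 96 mL.min-1.g-1
- compound 3 `CC1(C[C@@H](O)C(=O)N2C[C@H]3C[C@H]3[C@H]2C(=O)NCc2cc(Cl)ccc2-n2cnnn2)CC1`: 12 mL.min-1.g-1

Compound 3 has the lowest number of the three (12 mL.min-1.g-1), with compound 1 higher and compound 2 highest.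

The next compound is compound 4 `O=C(NCc1cc(Cl)ccc1-n1cnnn1)[C@@H]1[C@@H]2C[C@@H]2CN1C(=O)[C@H](O)Cc1ccccc1` and the change from compound 3 is (phenyl in place of 1-methylcyclopropyl on a saturated chain carbon, two bonds along the chain from a carbonyl carbon and an oxygen on a saturated carbon): phenyl in place of 1-methylcyclopropyl on a saturated chain carbon, two bonds along the chain from a carbonyl carbon and an oxygen on a saturated carbon.

Among the compounds with values here, the one measured step at this place is a 2.7-fold lower number from compound 1 to compound 3 (0.43 log units; beyond the scatter) and it brought in 1-methylcyclopropyl for propyl. That step involves no phenyl, so it gives only a rough sense of how far this place can move the number.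

Compound 2 is the closer guide, since it also carries benzyl at this place and gives 96 mL.min-1.g-1 in this assay. Within the data shown here, its structure is not identical to that of compound 4, and no measured step connects the two.

Among the measured compounds shown here, the expected step is a 6.7-fold higher number from compound 3 to compound 4 (0.82 log units; beyond the scatter) and it is expected to go to a higher number, larger than the one measured step. For compound 4 the estimated value is 80 mL.min-1.g-1 with an expected range from 35 mL.min-1.g-1 to 170 mL.min-1.g-1 in this assay.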

Compound 4, intrinsic clearance in microsomes: 74 mL.min-1.g-1
The estimate for compound 4 lay 1.1-fold (0.03 log units) above the measured number; the measured number falls inside the stated range.
By their numbers in this assay, from the lowest: compound 3; then compound 1; then compounds 4 and 2 (each within the scatter of the next).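

In this assay, within the data shown here, the place on the saturated chain carbon now reads in both directions: phenyl in place of 1-methylcyclopropyl gives a 6.2-fold higher number from compound 3 to compound 4 (0.79 log units; beyond the scatter) and phenyl in place of propyl gives a 2.3-fold higher number from compound 1 to compound 4 (0.36 log units; beyond the scatter), whereas the only earlier step at this place, a 2.7-fold lower number from compound 1 to compound 3 (0.43 log units; beyond the scatter), went to a lower number. Among the three groups compared on this configuration, phenyl therefore sits at the high end and 1-methylcyclopropyl at the low end, with propyl in the middle, and the step away from 1-methylcyclopropyl is the larger of the two steps to phenyl only as printed, not as a gap tested against the scatter. The step of a 1.3-fold lower number from compound 2 to compound 4 (0.11 log units; within the scatter) lies within the scatter, so the two stereocentres at saturated ring carbons show no separation in this read-out, and this pair rests on one fact: the fact that compounds 2 and 4 differ only in the configuration as drawn.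

The compounds shown leave open whether a pyridyl ring, an amine or a carboxylic acid at this place would stay near the phenyl compounds or fall nearer 1-methylcyclopropyl. They also leave open whether 1-methylcyclopropyl or propyl would read the same on the other drawn ring configuration.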